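The compounds below may be only part of what the source reports. "The series", "measured", "known", "first", "only" and "open" are said of these compounds alone.

Compound 1 `O=C(O)c1cc(-c2csnn2)ccc1O`: > 200 mg/kg
Compound 2 `O=C(O)c1cc(-c2ncc[nH]2)ccc1O`: 200 mg/kg

Within the data shown here, in a functional assay on the whole organism for inhibition, with Rattus norvegicus as the target, read by paw edema (on this read-out higher numbers stand for an effect only at larger amounts of compound and lower numbers for an effect already at smaller amounts), compound 2 gives 200 mg/kg, the only number among the two results. For compound 1 the value > 200 mg/kg is a limit of the assay, not a number. Among the measured compounds shown here, the one known step, a number no higher from compound 1 to compound 2 (the limit leaves the size open), rests on the limit of > 200 mg/kg in this assay, at which 1 of the 2 values shown sits, and has no readable size. Compound 3 `O=C(O)c1cc(-n2cccn2)ccc1O` differs from compound 2 by 1H-pyrazol-1-yl in place of 1H-imidazol-2-yl on an aromatic carbon. For the measured compounds named here, no measured step covers this change, so no shift beyond the scatter is expected: compound 3 is estimated at 200 mg/kg, within 100 mg/kg to 400 mg/kg, an expected step of no change at the digits printed from compound 2 to compound 3 (within the scatter).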

Compound 3, dose for half-maximal effect: 200 mg/kg
Estimate against measurement, compound 3: no gap at the digits printed, and the stated range covers the measured number.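

In this assay, 1H-pyrazol-1-yl in place of 1H-imidazol-2-yl on an aromatic carbon gives no change at the digits printed from compound 2 to compound 3 (within the scatter). The ring can thus be joined through nitrogen rather than carbon, and the hydrogen-bond donor of 1H-imidazol-2-yl can go, without any visible effect on this number. 1H-pyrazol-1-yl in place of 1,2,3-thiadiazol-4-yl on an aromatic carbon gives a number no higher from compound 1 to compound 3 (the limit leaves the size open). This step cannot be read, because it rests on a limit: the limit of > 200 mg/kg in this assay, at which 1 of the 3 values shown sits.

Still open, as far as these compounds go, is whether a group of another kind at this place, such as an amine or a longer alkyl chain, would act at smaller doses.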